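A few compounds are considered here, and "the series" means these few. Any claim that something is new, unique, unknown or untested is made for them only; others in the source may bear on it.

Measured so far: compound 1 `Cc1cc(-c2cccc([N+](=O)[O-])c2)c2ncc(CSCCc3ccccc3)n2c1`, giving 100 ug/mL in an ADME assay on HEL cells (Homo sapiens) for cytotoxicity, with a stated time of 3 days; a lower number here means that less compound is tolerated, a higher number that more compound is tolerated; compound 2 `Cc1cc(-c2ccc(O)cc2)cn2c(CSCCc3ccccc3)cnc12`, giving >= 100 ug/mL in this assay.

For compound 2 the value in this assay is a limit of the assay, not a number, so its position is known only as the limit of >= 100 ug/mL in this assay, at which 1 of the 2 values shown sits. Compound 1 reads at that same level. Compound 3 `Cc1cc(-c2cccc([N+](=O)[O-])c2)cn2c(CSCCc3ccccc3)cnc12` carries the change (3-nitrophenyl in place of 4-hydroxyphenyl on an aromatic carbon). Among the compounds with values here, no measured step covers this pair, and both measured compounds sit at the top of the range, so no step beyond the scatter is expected in this assay. Compound 3 is expected to give 100 ug/mL (range 50 ug/mL to 100 ug/mL), a step of a number no higher from compound 2 to compound 3 (the limit leaves the size open).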

Compound 3, minimum cytotoxic concentration: >= 100 ug/mL
Compound 3: only a limit was reported; the forecaster's own chance of this, stated with the estimate: 50%; the middle value sits exactly at the limit.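

In this assay compound 2 and compound 3 both stand only as limits of the assay, so no step can be read between them: the limit of >= 100 ug/mL in this assay, at which 2 of the 3 values shown sit. The compounds shown leave open how far either lies beyond that limit, and whether 3-nitrophenyl in place of 4-hydroxyphenyl shifts the value at all.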